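Adding a Chloro Group to Compound 1: What to Expect

This account rests on a few compounds, and the source may have more. Where it says the series, first, only, none or still open, it means among the compounds named here.

Compound 1 `CCN1C(=O)C(O)(Cc2nnn[nH]2)c2ccccc21` in a functional assay on PC-3 cells (Homo sapiens) for antiproliferative activity, read by MTT assay, with a stated time of 48 h; on this read-out higher numbers stand for weaker inhibition and lower numbers for stronger inhibition: > 100000 nM
Compound 2 `CN1C(=O)C(O)(Cc2nnn[nH]2)c2cc(F)ccc21`: 38200 nM
Compound 3 `O=C1N(Cc2ccc(Br)cc2)c2ccc(F)cc2C1(O)Cc1nnn[nH]1`: > 100000 nM

Compound 1 gives no number in this assay; its value is a limit of the assay, namely (the limit of > 100000 nM in this assay, at which 2 of the 3 values shown sit). Compound 3 also stands at a limit, > 100000 nM. Compound 2 is the only one of the three with a measured number, 38200 nM. Among the compounds with values here, the one measured step, an at least 2.6-fold higher number from compound 2 to compound 3 (0.41 log units; beyond the scatter), concerns a change at the ring nitrogen, not at the aromatic ring.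

Compound 4 `CCN1C(=O)C(O)(Cc2nnn[nH]2)c2cc(Cl)ccc21` is not yet measured. It differs from compound 1 by chloro in place of hydrogen on an aromatic carbon. No measured step carries this change, so nothing shown tells its size or direction. Within the data shown here, compound 2 carries a fluoro at an aromatic carbon together with a shorter group on the nitrogen, but no single step connects it to compound 1 or compound 4, so its value can only be noted as a number rather than a limit.

With compound 1 at a limit, the expectation for compound 4 is 70000 nM, within 30000 nM to 150000 nM, and the expected step is an at least 1.4-fold lower number from compound 1 to compound 4 (0.15 log units; that floor lies within the scatter), with a real chance that only a limit is reported again.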

Compound 4, half-maximal inhibitory concentration: 79300 nM
Estimate against measurement, compound 4: 1.1-fold (0.05 log units) below; low and high end bracket the measured number.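

Chloro in place of hydrogen on this aromatic carbon is the first change on the aromatic ring that can be read as a single step in this assay, and it gives a measured number where compound 1 has only a limit. The step is an at least 1.2-fold lower number from compound 1 to compound 4 (0.10 log units; that floor lies within the scatter), so the change shows no loss of activity, but its floor does not establish a real gain. Its true size stays unknown because compound 1 has no number of its own: the limit of > 100000 nM in this assay, at which 2 of the 4 values shown sit.

From the compounds shown here alone, whether a methyl, a methoxy or an amine on the same aromatic carbon would give a lower number than chloro remains open. Going by these compounds, compound 2 and compound 4 differ in two places, so it is also open how fluoro and chloro compare with the same group on the ring nitrogen.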